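Urea Aryl Extension in an Antiproliferative Oxadiazole Series

The source may report more compounds than this note shows. Statements on the series, on what has been measured and on what is new or still open speak of the compounds shown alone.

Measured so far:
- Compound 1 `CC(=O)Nc1ccc(S(=O)(=O)Nc2cccc(-c3nc(-c4ccc(NC(=O)c5cccnc5)cc4Cl)no3)c2)cc1C`: in a functional assay on MDA-MB-231 cells (Homo sapiens) for antiproliferative activity, read by MTT assay, with a stated time of 72 h (a higher number here means a weaker inhibitor, a lower number a stronger inhibitor), compound 1 gives > 10000 nM, which is a limit of the assay.
- Compound 2 `CCNC(=O)Nc1ccc(S(=O)(=O)Nc2cccc(-c3nc(-c4ccc(NC(=O)c5cccnc5)cc4Cl)no3)c2)cc1`: in this assay compound 2 gives 3100 nM.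
- Compound 3 `O=C(Nc1ccccc1)Nc1cccc(-c2nc(-c3ccc(NC(=O)c4cccnc4)cc3Cl)no2)c1`: in this assay compound 3 gives > 10000 nM, again a limit of the assay.

Compound 3 thus stands at the limit, as the limit of > 10000 nM in this assay, at which 2 of the 3 values shown sit, shows. Compound 4 `CC(=O)Nc1ccc(NC(=O)Nc2cccc(-c3nc(-c4ccc(NC(=O)c5cccnc5)cc4Cl)no3)c2)cc1Br` differs from compound 3 by 4-acetamido-3-bromophenyl in place of phenyl on an amide-type nitrogen. Within the data shown here, the only measured step, an at least 3.2-fold lower number from compound 1 to compound 2 (0.50 log units; beyond the scatter), touched the sulfonamide aryl and is not the same change, so it guides only loosely. For compound 4 a number near or at the limit is expected, with an at least 1.2-fold lower number from compound 3 to compound 4 (0.09 log units; that floor lies within the scatter). The estimated value for compound 4 in this assay is 8000 nM, between 2000 nM and 30000 nM.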

Compound 4, half-maximal inhibitory concentration: 1000 nM
The estimate for compound 4 lay 8.0-fold (0.90 log units) above the measured number; measured number below the stated range.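

In this assay, 4-acetamido-3-bromophenyl in place of phenyl on an amide-type nitrogen gives an at least 10-fold lower number from compound 3 to compound 4 (1.00 log units; beyond the scatter). Among these compounds, this position therefore responds to a change in its aryl group, whereas the only earlier step concerned the aryl group on the sulfonyl sulfur. The value of compound 3 is a limit of the assay, not a number: the limit of > 10000 nM in this assay, at which 2 of the 4 values shown sit.

The acetamido group and the bromine enter together, so the compounds shown do not separate their contributions. Going by these compounds, whether an amine in place of the acetamido group, or chlorine in place of the bromine, would preserve the activity of compound 4 remains open.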